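Notes on the aryl swap from compound 1 to compound 3

The source may report more compounds than this note shows. Statements on the series, on what has been measured and on what is new or still open speak of the compounds shown alone.

Measured compounds:
compound 1, `CS(=O)(=O)c1ccc(-c2cnc3[nH]cc(-c4nnc(-c5ccncc5)o4)c(=O)c3c2)cc1`, 29.2%
compound 2, `CS(=O)(=O)c1ccc(-c2cnc3[nH]cc(-c4nnc(-c5ccc(Cl)cc5)o4)c(=O)c3c2)cc1`, 24.9%
compound 3, `Cc1ccc(-c2nnc(-c3c[nH]c4ncc(-c5ccc(S(C)(=O)=O)cc5)cc4c3=O)o2)cc1`, not yet measured

In a functional assay on HCT-116 cells (Homo sapiens) for positive allosteric modulation, read by MTT assay, with stated times of 24 h and 48 h, tested at 2.5 uM (a lower number here means less inhibition of growth, a higher number more inhibition of growth at the concentration tested), compound 1 gives 29.2%, the highest of the two numbers in hand. Compound 2 gives 24.9% in this assay; the step of a number 4.3 percentage points lower from compound 1 to compound 2 (within the scatter) lies within the scatter, so the two values show no difference that can be read as real.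

Compound 3 differs from compound 1 by 4-methylphenyl in place of pyridin-4-yl on an aromatic carbon. Among the measured compounds shown here, the one measured step that bears on this change is a number 4.3 percentage points lower from compound 1 to compound 2 (within the scatter): there, too, the pyridin-4-yl at the same place was replaced by a carbon-only six-membered ring carrying a single substituent, and the number did not move beyond the scatter. On that basis no step beyond the scatter is expected for compound 3 in this assay; if anything a small drop of the same size as the chloro case is the natural guess. The step expected in this assay is a number 3.2 percentage points lower from compound 1 to compound 3 (within the scatter).

Compound 3 is therefore estimated at 26% in this assay, with a range from 14% to 38%.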

Compound 3, percent growth inhibition at one concentration: 54.8%
Beside the measured number, compound 3's estimate is 28.8 percentage points below it; measured number above the stated range.
By their numbers in this assay, from the lowest: compounds 2 and 1 (each within the scatter of the next); then compound 3.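

In this assay, the group on the aromatic carbon of the five-membered aromatic ring with 2 nitrogen and 1 oxygen now proves able to move the read-out: 4-methylphenyl in place of pyridin-4-yl gives a number 25.6 percentage points higher from compound 1 to compound 3 (beyond the scatter). Removing the ring nitrogen cannot be enough on its own, as 4-chlorophenyl in compound 2 also lacks it yet stays within the scatter of compound 1, and methyl in place of chloro gives a number 29.9 percentage points higher from compound 2 to compound 3 (beyond the scatter), so the identity of the single substituent on the carbon-only ring matters at this position. No evidence is at hand that bears on the reason for this difference.

From the compounds shown here alone, it remains open whether the rise is particular to methyl or extends to other substituents on the same ring, which an ethyl, a methoxy or a dimethylamino group in its place would help to settle. Also open, going by these compounds, is whether the rise in compound 3 holds at other concentrations in this assay, as the values here come from a single tested concentration.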